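The compounds below may be only part of what the source reports. "The series", "measured", "known", "first", "only" and "open" are said of these compounds alone.

Measured compounds in an assay on Sf9 cells for inhibition of inhibitor of nuclear factor kappa-B kinase subunit epsilon (Homo sapiens), read by ADP-Glo, with a stated time of 60 min; on this read-out lower numbers stand for stronger inhibition and higher numbers for weaker inhibition:
Compound 1 `Cc1n[nH]c(N)c1-c1ccc(Cl)cc1`. In this assay compound 1 reaches only the limit > 100000 nM.
Compound 2 `CC(=O)n1nc(C)c(-c2ccc(Cl)cc2)c1N`. In this assay compound 2 likewise reaches only the limit > 100000 nM.

Compound 2 thus stands at a limit of this assay, not at a number; the step that the two limits leave unreadable from compound 1 to compound 2 cannot be read, because both of its ends sit at the limit of > 100000 nM in this assay, at which 2 of the 2 values shown sit.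

Compound 3 `Cc1nn(C(=O)C2CC2)c(N)c1-c1ccc(Cl)cc1` has not been measured. It differs from compound 2 by cyclopropyl in place of methyl on a carbonyl carbon, so the acetyl of compound 2 becomes a cyclopropylcarbonyl. Among the compounds with values here, the one measured step, from compound 1 to compound 2 , bears on the same aromatic nitrogen but gives no readable size, so there is nothing from which to expect a shift beyond the scatter in this assay in either direction. The expectation for compound 3 is therefore that it stays at the limit, and the estimate is 150000 nM within 30000 nM to 1000000 nM. The estimated step that the limit leaves unreadable from compound 2 to compound 3 is expected to be none beyond the scatter.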

Compound 3, half-maximal inhibitory concentration: > 100000 nM
Compound 3 ended at the assay's limit; the forecaster's own chance of this, stated with the estimate: 85%; the middle value does not contradict the limit.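

No step among compound 1, compound 2 and compound 3 can be read in this assay, because all three stop at the same assay limit: the limit of > 100000 nM in this assay, at which 3 of the 3 values shown sit.

The compounds shown leave open whether any substituent on the aromatic nitrogen of the shared core gives a measurable value in this assay.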